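A Trifluoromethyl Group Added to an Unsubstituted Phenylpiperazine

The source may report more compounds than this note shows. Statements on the series, on what has been measured and on what is new or still open speak of the compounds shown alone.

In a functional assay on the whole organism (strain CD-1) with Mus musculus as the target, in the maximal electroshock model, with a stated time of 2 h (on this read-out higher numbers stand for an effect only at larger amounts of compound and lower numbers for an effect already at smaller amounts), compound 3 `CC1(c2ccccc2)CC(=O)N(CC(=O)N2CCN(c3ccccc3)CC2)C1=O` is reported as "not active" (no number reported), so no single number stands for it. Compound 4 `CC1(c2ccccc2)CC(=O)N(CC(=O)N2CCN(c3cccc(C(F)(F)F)c3)CC2)C1=O` differs from it by one change: trifluoromethyl in place of hydrogen on an aromatic carbon. Among the measured compounds shown here, the only measured step, no change at the digits printed from compound 1 to compound 2 (within the scatter), swaps one group for another at the same place and shows no change; in this assay compound 1 `Cc1cccc(N2CCN(C(=O)CN3C(=O)CC(C)(c4ccccc4)C3=O)CC2)c1` gives 300 mg/kg and compound 2 `CC1(c2ccccc2)CC(=O)N(CC(=O)N2CCN(c3cccc(Cl)c3)CC2)C1=O` gives 300 mg/kg. Both carry a group where compound 3 carries only hydrogen, and both reach a reported dose, whereas compound 3 does not. A trifluoromethyl group at that place is therefore expected to bring compound 4 back to a dose like those of the two substituted compounds, with no step beyond the scatter among them. Compound 4 is expected to give 300 mg/kg, in a range from 100 mg/kg to 600 mg/kg.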

Compound 4, minimum effective dose: 300 mg/kg
The estimate for compound 4 equals the measured number at the digits printed, and the stated range covers the measured number.
By their numbers in this assay, from the lowest: compounds 1, 2 and 4 (each within the scatter of the next).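

In this assay a third group at this place joins the other two: there is no change at the digits printed from compound 2 to compound 4 (within the scatter) and likewise no change at the digits printed from compound 1 to compound 4 (within the scatter) in the same read-out. Methyl, chloro and trifluoromethyl therefore cannot be told apart here, while the step from compound 3 to compound 4 cannot be read, since compound 3 has no number. No measurement at hand explains this sameness. The compounds shown leave open whether an amine or a carboxylic acid at this place would give a similar dose, and whether any group here could lower it.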